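Swapping Thiophene for Cyanophenyl on a Shared Core

The source may hold more compounds than are shown below. What is called first, only, known or untested is meant among the compounds shown, and "the series" means these compounds.

Compound 3 `Cc1cc(-c2cccs2)cn2c(CSCCc3ccccc3)cnc12` was assessed in an ADME assay on HEL cells (Homo sapiens) for cytotoxicity, with a stated time of 3 days (on this read-out lower numbers stand for higher toxicity in this test and higher numbers for lower toxicity in this test), where compound 3 gives 20 ug/mL. Its two neighbours give the same reading: compound 1 `Cc1cc(-c2ccc(O)cc2)c2ncc(CSCCc3ccccc3)n2c1` gives 20 ug/mL in this assay, and compound 2 `COc1cccc(-c2cc(C)c3ncc(CSCCc4ccccc4)n3c2)c1` gives 20 ug/mL, so compound 3 stands level with both, with no change beyond the scatter in either direction. Compound 4 `Cc1cc(-c2cccc(C#N)c2)cn2c(CSCCc3ccccc3)cnc12` differs from compound 3 in that (3-cyanophenyl in place of thiophen-2-yl on an aromatic carbon). Among the compounds with values here, the one measured step that bears on this, a ring exchange at the same position, is no change at the digits printed from compound 2 to compound 3 (within the scatter). Since that step left the read-out unchanged, no shift beyond the scatter is expected here either. Compound 4 is therefore expected to give 20 ug/mL in this assay, with a range from 10 ug/mL to 40 ug/mL. The expected step of no change at the digits printed from compound 3 to compound 4 (within the scatter) amounts to no change beyond the scatter.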

Compound 4, minimum cytotoxic concentration: > 100 ug/mL
Compound 4: a limit, no number (the forecaster's own chance of this, stated with the estimate: 10%); at least 5.0-fold (0.69 log units) between middle value and limit.
By their numbers in this assay, from the lowest: compounds 1, 2 and 3 (each within the scatter of the next). At a limit, above all of these: compound 4.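

Compound 4 shows that this assay does respond to the group on this aromatic carbon, since 3-cyanophenyl in place of thiophen-2-yl gives an at least 5.0-fold higher number from compound 3 to compound 4 (0.69 log units; beyond the scatter) and the earlier ring exchange had moved nothing beyond the scatter. Cyano in place of methoxy on an aromatic carbon gives an at least 5.0-fold higher number from compound 2 to compound 4 (0.69 log units; beyond the scatter) even though compound 2 and compound 3 read alike, so the difference goes with the nitrile-bearing ring. The reading of compound 4 is a limit and not a number: the limit of > 100 ug/mL in this assay, at which 1 of the 4 values shown sits.

As far as these compounds go, how far compound 4 lies past that limit stays open. So does whether an amine or a carboxylic acid in place of the cyano group would read like compound 4 or like compound 2.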